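The compounds below may be only part of what the source reports. "The series", "measured", "known", "first", "only" and "open" are said of these compounds alone.

Measured so far in a physicochemical assay for lipophilicity, using the shake flask method, in phosphate buffer, measured as octanol-water partition, with a stated time of 2 h, at pH 7.4, tested at 1 uM; on this read-out higher numbers stand for higher lipophilicity and lower numbers for lower lipophilicity:
Compound 1 (`COc1ccc2c(ccn2-c2ccc(O[C@H]3O[C@H](CO)[C@@H](O)[C@H](O)[C@@H]3O)c(Cl)c2)c1`): 3
Compound 2 (`OC[C@H]1O[C@H](Oc2ccc(-n3ccc4ccccc43)cc2F)[C@@H](O)[C@@H](O)[C@@H]1O`): 2.4

Compound 1 with 3 stands highest of the two, and compound 2 with 2.4 lies lower, by a gap beyond the scatter. Compound 1 and compound 2 differ in more than one place, so no single change can be read from them. Compound 3 (`CS(=O)(=O)Nc1ccc2c(ccn2-c2ccc(O[C@H]3O[C@H](CO)[C@@H](O)[C@H](O)[C@@H]3O)c(Cl)c2)c1`) has not yet been measured. Against compound 1 it carries methanesulfonamido in place of methoxy on an aromatic carbon of the shared core. Among the measured compounds shown here, no measured pair shows this change, so the expectation rests on the change itself, with compound 1 at 3 as the starting point. The step expected is a number 0.70 log units lower from compound 1 to compound 3 (beyond the scatter) in the downward direction, moderately beyond the scatter. Compound 3 is estimated at 2.3 in this assay as its middle value, with an expected range from 1.8 to 2.8 for repeated measurements.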

Compound 3, distribution coefficient: 1.8
Beside the measured number, compound 3's estimate is 0.50 log units above it; the range from low to high includes it.
By their numbers in this assay, from the lowest: compound 3; then compound 2; then compound 1.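

In this assay, among the compounds shown here, the change from methoxy to methanesulfonamido gives a number 1.20 log units lower from compound 1 to compound 3 (beyond the scatter) and is the first single change that can be read here. It shows that this place, on an aromatic carbon meta to a fused ring and para to a fused ring, can move the read-out substantially through one substitution while the rest of the shared core stays the same. No measurement at hand accounts for the size of this step.

The compounds shown leave open whether an amine, an acetamido group or a carboxylic acid at this place would lower the number as far. They also leave open whether the hydrogen-bond donor or the rest of methanesulfonamido carries the step, and whether it would recur on another core.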